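Solubility along the sulfonyl side chain

A few compounds are considered here, and "the series" means these few. Any claim that something is new, unique, unknown or untested is made for them only; others in the source may bear on it.

Compound 2 `CS(=O)(=O)c1ccc2nc(NC(=O)NC(=O)c3ccccc3Cl)sc2c1` stands at the floor of a physicochemical assay for solubility, at pH 7.4; on this read-out higher numbers stand for higher solubility and lower numbers for lower solubility: in this assay compound 2 gives < 470 nM, which is a limit of the assay and not a number. This is the limit of < 470 nM in this assay, at which 1 of the 2 values shown sits. Compound 1 `CN1CCCN(CCCS(=O)(=O)c2ccc3nc(NC(=O)NC(=O)c4ccccc4Cl)sc3c2)CC1`, by contrast, gives 340000 nM in this assay. Among the compounds with values here, the one measured step, an at least 720-fold lower number from compound 1 to compound 2 (2.85 log units; beyond the scatter), is the only guide on this read-out.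

Compound 3 `CC(C)NCCS(=O)(=O)c1ccc2nc(NC(=O)NC(=O)c3ccccc3Cl)sc2c1` differs from compound 2 by (isopropylamino)methyl in place of hydrogen on a saturated chain carbon bound to a sulfonyl sulfur. It thus carries a chain amine on the saturated carbon where compound 1 carries the 2-(4-methyl-1,4-diazepan-1-yl)ethyl and compound 2 carries hydrogen. Since the removal of that group gave the large step from compound 1 to compound 2, the expected step for compound 3 is estimated at about an at least 63-fold higher number from compound 2 to compound 3 (1.80 log units; beyond the scatter), which is less than the full span. Compound 3 is therefore estimated at 30000 nM, with a range from 2000 nM to 200000 nM.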

Compound 3, solubility: 71000 nM
Compound 3: middle estimate off by 2.4-fold (0.37 log units), on the low side, within the range that was stated.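

In this assay, high numbers are not tied to the 2-(4-methyl-1,4-diazepan-1-yl)ethyl group: (isopropylamino)methyl, which has no ring, in place of hydrogen on a saturated chain carbon bound to a sulfonyl sulfur gives an at least 150-fold higher number from compound 2 to compound 3 (2.17 log units; beyond the scatter). That step has only a lower bound, since compound 2 stands at a limit of the assay and not at a number: the limit of < 470 nM in this assay, at which 1 of the 3 values shown sits. Exchanging one chain amine for the other gives a 4.8-fold lower number from compound 1 to compound 3 (0.68 log units; beyond the scatter), a much smaller change than either step from compound 2, so in these compounds the choice of amine counts for less than having a chain amine at all.

On these data alone, whether the amine nitrogen is what matters remains open, as a hydroxyl or a carboxylic acid at the end of the chain would test. As far as these compounds go, how the number depends on the distance from the sulfonyl sulfur is also open, and a longer chain carrying isopropylamino would address that.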